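Swapping One Furan Group in Compound 2

The source may hold more compounds than are shown below. What is called first, only, known or untested is meant among the compounds shown, and "the series" means these compounds.

Compound 1 `Cc1ccsc1-c1cc(-c2ccoc2)cc(-c2ccco2)n1` gives 640 nM
Compound 2 `Cc1ccsc1-c1cc(-c2ccoc2)cc(-c2ccc(Cl)cc2)n1` gives 2990 nM
Compound 3 `Clc1ccc(-c2cc(-c3ccoc3)cc(-c3ccc(Cl)s3)n2)cc1` gives 640 nM

In a functional assay on HCT-15 cells (Homo sapiens) for cytotoxicity, read by ELISA, with a stated time of 4 days (on this read-out lower numbers stand for stronger inhibition and higher numbers for weaker inhibition), compound 2 gives the highest number of the three, and its gaps to both others lie beyond the scatter. Compound 4 `Cc1ccsc1-c1cc(-c2ccc(Cl)o2)cc(-c2ccc(Cl)cc2)n1` differs from it in one place, opposite the ring nitrogen, with 5-chlorofuran-2-yl in place of furan-3-yl (5-chlorofuran-2-yl in place of furan-3-yl on an aromatic carbon). Among the compounds with values here, no measured step touches that place. The nearest guides are modest changes elsewhere: a 4.7-fold higher number from compound 1 to compound 2 (0.67 log units; beyond the scatter) with 4-chlorophenyl entering, and a 4.7-fold lower number from compound 2 to compound 3 (0.67 log units; beyond the scatter) with 5-chlorothiophen-2-yl entering. That second step also brought in a chlorine-bearing five-membered ring, so a smaller fall is expected, though with little certainty. The expected step is a 1.8-fold lower number from compound 2 to compound 4 (0.25 log units; within the scatter). Compound 4 is estimated at 1700 nM (expected range 600 nM to 4500 nM).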

Compound 4, half-maximal inhibitory concentration: 30300 nM
Compound 4: middle estimate off by 18-fold (1.25 log units), on the low side; the measured number lies above the stated range.
By their numbers in this assay, from the lowest: compounds 1 and 3 (each within the scatter of the next); then compound 2; then compound 4.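

This place opposite the ring nitrogen had not been probed before, and in this assay it proves sensitive: the step is a 10-fold higher number from compound 2 to compound 4 (1.01 log units; beyond the scatter) with 5-chlorofuran-2-yl in place of furan-3-yl. A chlorine-bearing five-membered ring lowered the number when it replaced 3-methylthiophen-2-yl in compound 3, yet raises it here, so that gain does not carry over to this place.

On these data alone, whether the rise comes from the chlorine or from the shift from furan-3-yl to furan-2-yl stays open, as does how an amine or a carboxylic acid would fare here. No measurement shown gives a reason for the rise.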